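The compounds below may be only part of what the source reports. "The series", "measured", "known", "first", "only" and "open" are said of these compounds alone.

Measured compounds:
- compound 1, `O=C(CCCCCCc1ccccc1)c1ncc(-c2ccc(CO)cn2)o1`, gives 3.2 nM in an assay for inhibition of Fatty-acid amide hydrolase 1 (Rattus norvegicus), using a Dixon plot; a higher number here means a weaker inhibitor, a lower number a stronger inhibitor
- compound 2, `O=C(CCCCCCc1ccccc1)c1ncc(-c2ccc(CCl)cn2)o1`, gives 22.4 nM in this assay
- compound 3, `COC(=O)CCCCc1cnc(C(=O)CCCCCCc2ccccc2)o1`, gives 1.8 nM in this assay

Compound 3 shows the lowest of the three numbers in this assay. Its nearest neighbour is compound 1, and that gap, a 1.8-fold lower number from compound 1 to compound 3 (0.25 log units; within the scatter), does not count as a real difference. Compound 2 is further off: a 12-fold lower number from compound 2 to compound 3 (1.09 log units; beyond the scatter), a clear gap. Within the pyridine pair, the swap a 7.0-fold higher number from compound 1 to compound 2 (0.85 log units; beyond the scatter) is also beyond the scatter.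

Compound 4, `CSC(=O)CCCCc1cnc(C(=O)CCCCCCc2ccccc2)o1`, is compound 3 with one alteration: methylsulfanyl in place of methoxy on a carbonyl carbon. None of the three measured steps touches the carbonyl carbon or its methoxy group; the two that alter the same side of the core exchange whole tail groups, and the third changes a group on a ring that compound 3 and compound 4 do not carry. The only loose parallel is the hydroxy-to-chloro swap, which weakened binding, but it sits on a different kind of atom and offers no firm guide. The change here is small in count and keeps one hydrogen-bond acceptor, so the expected step of a 1.7-fold higher number from compound 3 to compound 4 (0.22 log units; within the scatter) is modest and uncertain in direction. Compound 4 is therefore estimated at 3 nM, with a plausible range from 0.8 nM to 12 nM.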

Compound 4, inhibition constant: 1.8 nM
Compound 4: middle estimate off by 1.7-fold (0.22 log units), on the high side; measured number inside the range.
By their numbers in this assay, from the lowest: compounds 3, 4 and 1 (each within the scatter of the next); then compound 2.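

Among the compounds shown here, replacing methoxy with methylsulfanyl on this carbonyl carbon leaves the number in this assay unmoved (no change at the digits printed from compound 3 to compound 4 (within the scatter)), which the earlier compounds could not show, as none of their steps touched this carbonyl carbon or the group on it. In this tail, methoxycarbonyl and (methylsulfanyl)carbonyl therefore cannot be told apart by this assay, and the sulfur-bearing tail stands where the methoxy one stood against the two compounds with the aromatic ring: one gap is large (a 12-fold lower number from compound 2 to compound 4 (1.09 log units; beyond the scatter)), and the other is no real difference (a 1.8-fold lower number from compound 1 to compound 4 (0.25 log units; within the scatter)). Nothing in the data says why this exchange leaves the number in place.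

The compounds shown leave open whether the number would also hold with other groups on this carbonyl carbon, such as an amine, which would make an amide, or a hydroxy group, which would make a carboxylic acid. They also leave open whether methoxy and methylsulfanyl would still match on a longer chain, since this single pair speaks for one tail only.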